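Sulfonamide series: three limits and one untested analogue

The source may report more compounds than this note shows. Statements on the series, on what has been measured and on what is new or still open speak of the compounds shown alone.

The series is read in an assay on isolated protein for inhibition of malate dehydrogenase, mitochondrial (Sus scrofa), with stated times of 45 min and 30 min; a higher number here means a weaker inhibitor, a lower number a stronger inhibitor. Compound 1 `C=Cc1ccc(S(=O)(=O)Nc2ccc3oc(-c4ccccc4)nc3c2)cc1` gives in this assay > 63000 nM, which is a limit of the assay and not a measured number. Compound 2 `O=S(=O)(Nc1ccc(-c2nc3ccccc3o2)cc1)c1ccccc1F` likewise returns in this assay > 63000 nM, again a limit. Compound 3 `O=[N+]([O-])c1cc(S(=O)(=O)Nc2ccc(-c3nc4ccccc4o3)cc2)ccc1Cl` gives in this assay > 63000 nM, also a limit. Compound 1 therefore stands nowhere in particular on the numbers shown: all three values sit at the same limit (the limit of > 63000 nM in this assay, at which 3 of the 3 values shown sit), and no step between measured compounds can be given, since none of the three values is a number.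

Compound 4 `COc1ccc(Cl)cc1S(=O)(=O)Nc1ccc2oc(-c3ccccc3)nc2c1` is still to be measured in this assay. It differs from compound 1 in one place:
5-chloro-2-methoxyphenyl in place of 4-vinylphenyl on a sulfonyl sulfur
Among the measured compounds shown here, no measured step informs this change; the only guide is that every compound measured so far sits at the limit (the limit of > 63000 nM in this assay, at which 3 of the 3 values shown sit), whatever group stands on the sulfonyl sulfur. The step expected from this change, a step that the limit leaves unreadable from compound 1 to compound 4, is none beyond the scatter, and the likeliest outcome for compound 4 is another limit rather than a number. Compound 4 is estimated in this assay at 100000 nM, within a range from 30000 nM to 300000 nM.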

Compound 4, half-maximal inhibitory concentration: > 63000 nM
Compound 4 ended at the assay's limit; the forecaster's own chance of this, stated with the estimate: 80%; the middle value does not contradict the limit.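

In this assay compound 4 gives > 63000 nM as a limit of the assay and not a number. Among the compounds shown here, no step from compound 1 to compound 4 can be read, since both stand at the same limit: the limit of > 63000 nM in this assay, at which 4 of the 4 values shown sit.

The compounds shown leave open which group on the sulfonyl sulfur, if any, would give a measurable value in this assay.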